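Urea to thiourea swap on the ring nitrogen

The compounds below may be only part of what the source reports. "The series", "measured", "known", "first", "only" and "open" are said of these compounds alone.

Measured compounds:
compound 1, `Cc1ccccc1CN1CCc2c(sc(NC(=O)c3ccccc3Cl)c2C(N)=O)C1`: > 50000 nM in a functional assay on HL-60 cells (Homo sapiens) for antiproliferative activity, with a stated time of 24 h; on this read-out lower numbers stand for stronger inhibition and higher numbers for weaker inhibition
compound 2, `NC(=O)c1c(NC(=O)c2ccccc2Cl)sc2c1CCN(C(=S)Nc1cccc3ccccc13)C2`: 13400 nM
compound 3, `NC(=O)c1c(NC(=O)c2ccccc2Cl)sc2c1CCN(C(=O)Nc1ccccc1Cl)C2`: 12500 nM

In this assay compound 1 reaches only a limit, > 50000 nM, and no number. Compound 3 stands at the lowest of the two numbers shown, and compound 2 sits within the usual scatter of it, so the two cannot be ranked. Among the measured compounds shown here, the one step measured with a single change is an at least 4.0-fold lower number from compound 1 to compound 3 (0.60 log units; beyond the scatter), and compound 1 there gives only a limit, (the limit of > 50000 nM in this assay, at which 1 of the 3 values shown sits), so the size of that step is itself a lower bound.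

Compound 4, `COc1ccc(NC(=S)N2CCc3c(sc(NC(=O)c4ccccc4Cl)c3C(N)=O)C2)cc1`, is not yet measured. It differs from compound 3 in this way: a group of 11 heavy atoms (8 carbon, 1 nitrogen, 1 oxygen, 1 sulfur; one six-membered aromatic ring of carbon only) in place of a group of 10 heavy atoms (7 carbon, 1 nitrogen, 1 oxygen, 1 chlorine; one six-membered aromatic ring of carbon only), on an amine nitrogen in a ring The measured step from compound 1 to compound 3 does not bear directly on this change, since it exchanges a benzyl for a carbamoyl group rather than one carbamoyl-type group for another. The best guide is that compound 2, which also carries a thiocarbamoyl group on the same ring nitrogen, gives 13400 nM, within the scatter of compound 3. No step beyond the scatter is therefore expected in this assay, in either direction. Compound 4 is expected to give 14000 nM, with a likely range from 5000 nM to 45000 nM. That estimate means a step of a 1.1-fold higher number from compound 3 to compound 4 (0.05 log units; within the scatter), expected to stay within the scatter.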

Compound 4, half-maximal inhibitory concentration: 15700 nM
Beside the measured number, compound 4's estimate is 1.1-fold (0.05 log units) below it; the range from low to high includes it.
By their numbers in this assay, from the lowest: compounds 3, 2 and 4 (each within the scatter of the next). At a limit, above all of these: compound 1.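

In this assay, the change on the amine nitrogen in a ring gives a 1.3-fold higher number from compound 3 to compound 4 (0.10 log units; within the scatter), so a thiocarbamoyl group bearing 4-methoxyphenyl and the (2-chlorophenyl)carbamoyl group cannot be told apart at this position. Among the compounds shown here, with the thiocarbamoyl group kept, the exchange on the amide-type nitrogen gives a 1.2-fold higher number from compound 2 to compound 4 (0.07 log units; within the scatter), so 4-methoxyphenyl and naphthalen-1-yl cannot be told apart here either, which the earlier compounds offered no single-place pair to show. Against the 2-methylbenzyl group of compound 1, the result is an at least 3.1-fold lower number from compound 1 to compound 4 (0.50 log units; beyond the scatter), a second carbamoyl-type group on that ring nitrogen to stand clear of the benzyl group, and the size of this step is only a lower bound, as compound 1 gives a limit: the limit of > 50000 nM in this assay, at which 1 of the 4 values shown sits.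

The compounds shown leave open whether a cyclohexyl group or a longer chain in place of the aromatic ring on the amide-type nitrogen would keep these values, and whether an amine or a carboxylic acid on that ring would shift them. The exchange of oxygen for sulfur also cannot be read alone, since no pair shown differs in that atom only.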